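The compounds below may be only part of what the source reports. "The series", "measured", "known", "first", "only" and "open" are said of these compounds alone.

Compound 1 `COc1ccc(/C=C\c2cc(OC)c(OC)c(OC)c2)cc1OCc1ccc(CN[C@H](C(=O)O)[C@H](C)O)cc1` and compound 2 `COc1ccc(/C=C\c2cc(OC)c(OC)c(OC)c2)cc1OCc1ccc(CN2CCCCC2C(=O)O)cc1` share one core and differ only in the group carried on a saturated chain carbon bound to an aromatic carbon. In a functional assay on HeLa cells (Homo sapiens) for antiproliferative activity, read by CCK-8 assay, with a stated time of 48 h (on this read-out higher numbers stand for weaker inhibition and lower numbers for stronger inhibition), compound 1 gives only a limit, > 10000 nM, so no number is known for it. In this assay, going by the values given here, compound 2 gives 14200 nM, the only number among the two values shown, and that number stands for weak inhibition. The step that the limit leaves unreadable from compound 1 to compound 2 cannot be sized because the limit of > 10000 nM in this assay, at which 1 of the 2 values shown sits, sits at one end of it.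

Compound 3 `COc1ccc(/C=C\c2cc(OC)c(OC)c(OC)c2)cc1OCc1ccc(CN2CC[C@@H](C(=O)O)C2)cc1` has not yet been measured; it differs from compound 2 in one place: 3-carboxypyrrolidin-1-yl in place of 2-carboxypiperidin-1-yl on a saturated chain carbon bound to an aromatic carbon. The one six-membered non-aromatic ring with 1 hetero atom leaves, and one five-membered non-aromatic ring with 1 hetero atom enters. No measured step bears directly on this change, since the only step shown is unreadable, so no direction beyond the scatter is expected. From compound 2 to compound 3 the expected step is a 1.2-fold lower number from compound 2 to compound 3 (0.07 log units; within the scatter). Compound 3 is therefore estimated at 12000 nM, expected to lie between 4000 nM and 40000 nM.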

Compound 3, half-maximal inhibitory concentration: 12800 nM
The estimate for compound 3 lay 1.1-fold (0.03 log units) below the measured number, within the range that was stated.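

Replacing 2-carboxypiperidin-1-yl with 3-carboxypyrrolidin-1-yl on a saturated chain carbon bound to an aromatic carbon gives, in this assay, a 1.1-fold lower number from compound 2 to compound 3 (0.05 log units; within the scatter). Going by these compounds alone, this is the first step that can be sized, and at this place the six-membered and the five-membered non-aromatic ring, each with 1 hetero atom and a carboxy group, cannot be told apart, with inhibition weak for both compounds. Compound 1 gives only a limit, and the steps from it to compound 2 and to compound 3 cannot be read because of that limit: the limit of > 10000 nM in this assay, at which 1 of the 3 values shown sits.

The compounds shown leave open how the number would respond at this place to a group without the carboxylic acid, such as a methyl ester or a plain piperidin-1-yl. As far as these compounds go, it is also open which part of the change counts: ring size and the place of the carboxy group change together in this one step, and a 3-carboxypiperidin-1-yl group would pull the two apart.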